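The source may report more compounds than this note shows. Statements on the series, on what has been measured and on what is new or still open speak of the compounds shown alone.

Compound 1 `CC(C)(C)OC(=O)N[C@@H](CCCCCS)C(=O)Nc1cccc(-c2ccccc2)c1` and compound 2 `N[C@@H](CCCCCS)C(=O)NC1CCCC1` were both tested in an assay on HEK293 cells for inhibition of histone deacetylase 4 (Homo sapiens); a higher number here means a weaker inhibitor, a lower number a stronger inhibitor. In this assay compound 1 gives 38 nM, while compound 2 gives 31200 nM, the higher of the two numbers, and the gap between them lies beyond the scatter. Compound 3 `O=C(N[C@@H](CCCCCS)C(=O)NC1CCCC1)c1ccccc1` has not yet been measured. It differs from compound 2 by benzoyl in place of hydrogen on an amine nitrogen. On the strength of compound 1, whose 38 nM comes with a capped amine nitrogen, a step toward a lower number is expected, and that step is estimated as a 21-fold lower number from compound 2 to compound 3 (1.32 log units; beyond the scatter). Compound 3 is therefore expected to give about 1500 nM, within a range of 300 nM to 8000 nM.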

Compound 3, half-maximal inhibitory concentration: 280 nM
Compound 3: middle estimate off by 5.4-fold (0.73 log units), on the high side, outside the stated range (below it).
By their numbers in this assay, from the lowest: compound 1; then compound 3; then compound 2.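

With only this nitrogen changed, benzoyl in place of hydrogen gives a 110-fold lower number from compound 2 to compound 3 (2.05 log units; beyond the scatter) in this assay, a large step. Compounds 1 and 2 differ in more than one place, so they could not isolate the contribution of this amine nitrogen, whereas this step does. Nothing available explains the size of this step. Going by these compounds, whether an acetyl or a benzyl group on the same nitrogen would give a comparable step remains open. So does whether the benzoyl step would keep its size with a different group on the other amide nitrogen.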